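The compounds below may be only part of what the source reports. "The series", "measured", "known", "first", "only" and "open" are said of these compounds alone.

Measured compounds:
compound 1 `O=[N+]([O-])c1ccc(O)c(/C=N/Nc2nc3ccccc3s2)c1` — 14000 nM
compound 2 `COc1cc(/C=N/Nc2nc3ccccc3s2)ccc1O` — > 16700 nM (a limit of the assay, not a number)

In a functional assay on MDA-MB-435 cells (Homo sapiens) for cytotoxicity, read by MTT assay, with a stated time of 72 h (a higher number here means a weaker inhibitor, a lower number a stronger inhibitor), compound 1 gives 14000 nM. For compound 2 the value > 16700 nM is a limit of the assay and not a number; (the limit of > 16700 nM in this assay, at which 1 of the 2 values shown sits). Compound 2 therefore stands at the edge of what this assay reports, with no measured number to place it against compound 1.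

Compound 3 `Oc1ccc(/C=N/Nc2nc3ccccc3s2)cc1O` is the next member of the series. Relative to compound 2 the change is hydrogen in place of methyl on an oxygen on an aromatic ring. Among the compounds with values here, no step between two measured compounds that differ in one place is available, so there is no measured precedent for the size of this change.

The expected step of an at least 1.0-fold lower number from compound 2 to compound 3 (0.01 log units; that floor lies within the scatter) is none beyond the usual scatter, with a real chance that this assay again reports only a limit. Compound 3 is therefore estimated at 16000 nM, within a range from 6000 nM to 45000 nM.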

Compound 3, half-maximal inhibitory concentration: > 17500 nM
Compound 3: no number, only a limit (the forecaster's own chance of this, stated with the estimate: 50%); at least 1.0-fold (0.03 log units) between middle value and limit.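

In this assay compound 3 gives > 17500 nM, a limit of the assay and not a number. Compound 2 and compound 3 both stand only at limits, and no step can be read between them. On these data alone, whether methoxy to hydroxy changes cytotoxicity at all stays open.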